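The compounds below may be only part of what the source reports. "The series", "measured", "known", "first", "only" and "open" are said of these compounds alone.

Measured in a functional assay on SW1573 cells (Homo sapiens) for antiproliferative activity, read by sulforhodamine B assay, with a stated time of 48 h; on this read-out lower numbers stand for stronger inhibition of growth and higher numbers for weaker inhibition of growth:
Compound 1 `CC(C)(C)[Si](C)(C)OC[C@H]1OCCC[C@H]1O[Si](C)(C)C(C)(C)C`: > 100000 nM, a limit
Compound 2 `CC(C)(C)[Si](C)(C)O[C@@H]1CCCO[C@@H]1/C=C\C(=O)OCc1ccccc1`: 26000 nM
Compound 3 `CC(C)(C)[Si](C)(C)O[C@@H]1CCCO[C@@H]1/C=C\CO`: > 100000 nM, a limit

Compound 3 gives > 100000 nM, which is a limit and not a number. Compound 4 `C=C[C@H]1OCCC[C@H]1O[Si](C)(C)C(C)(C)C` carries vinyl in place of 3-hydroxyprop-1-en-1-yl on a saturated ring carbon. No change beyond the scatter is expected in this assay, so the estimated at least 1.2-fold lower number from compound 3 to compound 4 (0.09 log units; that floor lies within the scatter) is small. This expectation rests on compound 3 sitting at the limit of > 100000 nM in this assay, at which 2 of the 3 values shown sit. For the measured compounds named here, compound 2, at 26000 nM, goes against this pattern and is the only compound with a number. For compound 4 the estimate is 80000 nM, with an expected range of 25000 nM to 200000 nM, though a reading that is only a limit is quite possible.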

Compound 4, concentration for 50% growth inhibition: > 100000 nM
Compound 4 ended at the assay's limit; the forecaster's own chance of this, stated with the estimate: 65%; middle value at least 1.2-fold (0.09 log units) away from the limit.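

Compound 3 and compound 4 both end at a limit of the assay, and the step between them cannot be read. The compounds shown leave open whether vinyl in place of 3-hydroxyprop-1-en-1-yl changes growth inhibition at all.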